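Smaller group on the core: from compound 2 to compound 3

A few compounds are considered here, and "the series" means these few. Any claim that something is new, unique, unknown or untested is made for them only; others in the source may bear on it.

Measured so far:
compound 1, `NC(=O)COc1cc(=O)oc2cc(OCc3cccc(Br)c3)ccc12`, gives 8.91 nM in an assay on isolated protein (strain Sprague-Dawley) for inhibition of Amine oxidase [flavin-containing] B (Rattus norvegicus), read by spectrophotometry, with a stated time of 5 min; on this read-out lower numbers stand for stronger inhibition and higher numbers for weaker inhibition.
compound 2, `CN(C)C(=O)COc1cc(=O)oc2cc(OCc3cccc(Cl)c3)ccc12`, gives 501 nM in this assay.

Compound 2 stands at the highest of the two numbers, so of the two measured compounds it is the weaker inhibitor; compound 1 lies well beyond the usual scatter below it. Compound 3, `O=c1cc(CO)c2ccc(OCc3cccc(Cl)c3)cc2o1`, has not yet been measured. It differs from compound 2 in one place: hydroxymethyl in place of (dimethylcarbamoyl)methoxy on an aromatic carbon. Going by the values given here, no step between two measured compounds is known that would show what such a change does, so the expectation rests on the two values alone. Among the compounds with values here, compound 1, the only compound with a hydrogen-bond donor in this part of the structure, gives 8.91 nM, and compound 3 also carries a donor there. Compound 3 is therefore expected to move toward that number, with a step of an 8.4-fold lower number from compound 2 to compound 3 (0.92 log units; beyond the scatter) estimated. The estimate for compound 3 is 60 nM, within a range from 6 nM to 600 nM.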

Compound 3, half-maximal inhibitory concentration: 5.25 nM
Estimate against measurement, compound 3: 11-fold (1.06 log units) above; the whole stated range lies above it.
By their numbers in this assay, from the lowest: compounds 3 and 1 (each within the scatter of the next); then compound 2.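

In this assay, putting hydroxymethyl in place of (dimethylcarbamoyl)methoxy on the aromatic carbon opposite the ring oxygen gives a large change, a 95-fold lower number from compound 2 to compound 3 (1.98 log units; beyond the scatter). Going by these compounds alone, this is the first step between two measured compounds that differ in one place, and it shows directly that the number depends strongly on the group at this position. It also shows that a group of 2 heavy atoms, replacing one of 7, can give a far lower number here, although nothing available explains why.

This single step changes chain length, the amide and the hydrogen-bond donor count all at once, so it cannot say which of these matters. A methyl, a methoxymethyl or an aminomethyl group at this position would help to tell these apart.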